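The source may report more compounds than this note shows. Statements on the series, on what has been measured and on what is new or still open speak of the compounds shown alone.

In an assay (Equus caballus) for inhibition of Thromboxane-A synthase (Homo sapiens), using microsomes (a higher number here means a weaker inhibitor, a lower number a stronger inhibitor), three compounds have been measured:

compound 1 `NC(=O)CCCC/C=C(\c1ccccc1)c1cccnc1` gives 400 nM
compound 2 `C=C(C)C(CCC/C=C(\c1ccccc1)c1cccnc1)C(=O)O` gives 28 nM
compound 3 `CC(C)(CCC/C=C(\c1ccccc1)c1cccnc1)C(=O)O` gives 21 nM

Compound 2 stands second highest of these three numbers. Its nearest neighbour is compound 3, reached by a 1.3-fold lower number from compound 2 to compound 3 (0.12 log units; within the scatter), a step within the scatter, so the two cannot be told apart. Its furthest neighbour is compound 1: the step of a 14-fold lower number from compound 1 to compound 2 (1.15 log units; beyond the scatter) is large, as is the parallel step a 19-fold lower number from compound 1 to compound 3 (1.28 log units; beyond the scatter), and both show that a carboxylic acid on a branched chain carbon goes with far lower numbers than a carbamoylmethyl end.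

Compound 4 `CC(C)CSC(CCC/C=C(\c1ccccc1)c1cccnc1)C(=O)O` keeps that carboxylic acid and changes only the branch: isobutylsulfanyl in place of 1-methylethenyl on a saturated chain carbon bound to a carbonyl carbon and a saturated chain carbon. Among the compounds with values here, the step from compound 2 to compound 3, which also swaps the group on that carbon, was within the scatter, which suggests such swaps move the number little; no measured step, however, introduces a sulfur-containing group, so the expectation is loose. Compound 4 is expected to show a 1.1-fold lower number from compound 2 to compound 4 (0.05 log units; within the scatter), essentially no step beyond the scatter. The estimate for compound 4 in this assay is 25 nM, with a range from 8 nM to 80 nM.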

Compound 4, half-maximal inhibitory concentration: 110 nM
Compound 4: the middle estimate sits 4.4-fold (0.64 log units) below what was measured; measured number outside the range, above it.
By their numbers in this assay, from the lowest: compounds 3 and 2 (each within the scatter of the next); then compound 4; then compound 1.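

In this assay, the group on this chain carbon cannot be swapped freely. Replacing 1-methylethenyl with isobutylsulfanyl gives a 3.9-fold higher number from compound 2 to compound 4 (0.59 log units; beyond the scatter), a modest step beyond the scatter, whereas the change to 1-carboxy-1-methylethyl gave a 1.3-fold lower number from compound 2 to compound 3 (0.12 log units; within the scatter), which lies within it. Keeping the carboxylic acid is therefore not enough on its own to hold the number where compound 2 has it, and no separate measurement is available to explain the rise.

The change brings in a sulfur atom and also enlarges the group from 3 to 5 heavy atoms, and the compounds shown do not separate these two differences. On these data alone, a methylsulfanyl group or a plain isobutyl group on this carbon would pull them apart, and how an amine there would behave also remains open.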